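The compounds below may be only part of what the source reports. "The series", "measured", "known", "first", "only" and "open" are said of these compounds alone.

Compound 2 `CCN(Cc1ccoc1)C(=O)COc1ccc(C)cc1` stands lowest of the two numbers obtained in an assay on HEK293 cells for agonist activity at transient receptor potential cation channel subfamily M member 8 (Homo sapiens), read by fluorescence and calcium flux, with a stated time of 15 min; on this read-out higher numbers stand for an effect only at larger amounts of compound and lower numbers for an effect already at smaller amounts: compound 2 gives 136 nM, whereas compound 1 `CCN(Cc1cccs1)C(=O)COc1ccc(F)cc1` gives 422 nM, a gap beyond the scatter. Compound 3 `CCN(Cc1cccnc1)C(=O)COc1ccc(C)cc1` has not yet been measured; it differs from compound 2 by pyridin-3-yl in place of furan-3-yl on a saturated chain carbon bound to an amide-type nitrogen. Among the measured compounds shown here, no measured pair carries this same change, so its effect has no precedent here. The step of a 1.8-fold higher number from compound 2 to compound 3 (0.26 log units; within the scatter) is expected to be modest, with no clear direction. For compound 3 the estimate in this assay is 250 nM, within a range from 80 nM to 800 nM.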

Compound 3, half-maximal effective concentration: 15400 nM
Compound 3: the middle estimate sits 62-fold (1.79 log units) below what was measured; the whole stated range lies below it.
By their numbers in this assay, from the lowest: compound 2; then compound 1; then compound 3.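

Pyridin-3-yl in place of furan-3-yl on a saturated chain carbon bound to an amide-type nitrogen gives a 110-fold higher number from compound 2 to compound 3 (2.05 log units; beyond the scatter) in this assay. Among the compounds shown here, this is the first change here confined to one place, and it shows that this place alone can shift the number far beyond the scatter, even though the hetero atom count and the acceptor count stay the same. Nothing available explains the step. The compounds shown leave open whether the step follows the six-membered ring or its nitrogen; a phenyl group at this place would separate the two.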